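The source may hold more compounds than are shown below. What is called first, only, known or untested is meant among the compounds shown, and "the series" means these compounds.

Among the compounds with values here, compound 2 `Cc1cc(Cl)ccc1OC[C@H](N)c1ccccc1` gives the lowest of the two numbers so far in an assay on isolated protein for inhibition of sodium channel protein type 4 subunit alpha (Homo sapiens) (a lower number here means that less compound is needed, a higher number that more compound is needed for the effect), with compound 2 at 15100 nM; the nearest neighbour is compound 1 `Cc1cc(Cl)cc(C)c1OC[C@H](N)c1ccccc1`, where compound 1 reaches 19500 nM. The step of a 1.3-fold lower number from compound 1 to compound 2 (0.11 log units; within the scatter) removed one methyl and stayed within the scatter. Compound 3 `N[C@@H](COc1ccc(Cl)cc1)c1ccccc1` repeats that change on the other side: hydrogen in place of methyl on an aromatic carbon. Within the data shown here, only that single step bears on it, and it was small, so no step beyond the scatter is expected in this assay, a 1.2-fold lower number from compound 2 to compound 3 (0.07 log units; within the scatter). Compound 3 is therefore estimated at 13000 nM, with a range from 6000 nM to 30000 nM.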

Compound 3, half-maximal effective concentration: 10000 nM
Compound 3: the middle estimate sits 1.3-fold (0.11 log units) above what was measured; low and high end bracket the measured number.
By their numbers in this assay, from the lowest: compounds 3, 2 and 1 (each within the scatter of the next).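

The second replacement of methyl by hydrogen on an aromatic carbon gives a 1.5-fold lower number from compound 2 to compound 3 (0.18 log units; within the scatter) in this assay and so stays within the scatter, as the first replacement did. Compound 3 carries neither methyl, and at this place, ortho to a large group, neither removal gives a step beyond the scatter. Nothing available here bears on a cause for these small steps.

As far as these compounds go, whether a methoxy, a trifluoromethyl or an amine at this place gives a step beyond the scatter remains open. So does the effect of replacing the chloro group.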